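Larger Side Groups on a Shared Nucleoside Core

The compounds below may be only part of what the source reports. "The series", "measured", "known", "first", "only" and "open" are said of these compounds alone.

Measured compounds and their values:
Compound 1, `CC(=O)OC[C@H]1O[C@@H](n2cc(-c3cn(Cc4ccccc4)nn3)c(=O)[nH]c2=O)C[C@@H]1OC(C)=O`: 98.2%
Compound 2, `CCCCCCCCc1cc(-c2cn([C@H]3C[C@H](O)[C@@H](CO)O3)c(=O)[nH]c2=O)on1`: 120%
Compound 3, `CC(=O)OC[C@H]1O[C@@H](n2cc(-c3cc(C)no3)c(=O)[nH]c2=O)C[C@@H]1OC(C)=O`: 101%

All three were tested in a functional assay on NCI-H23 cells (Homo sapiens) for cytotoxicity, read by sulforhodamine B assay, tested at 10 uM; a higher number here means more inhibition at the concentration tested (going by the name of the read-out), a lower number less inhibition. In this assay compound 3 gives 101%. Compound 1 gives 98.2%, and this number lies within the usual scatter of compound 3, so the two cannot be told apart. Compound 2 gives 120%, a number that stands beyond the scatter above compound 3. No two of these compounds differ in only one place, so no single step between measured compounds can be read off.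

Compound 4, `CCc1ccc(-c2cc(-c3cn([C@H]4C[C@H](OC(C)=O)[C@@H](COC(C)=O)O4)c(=O)[nH]c3=O)on2)cc1`, has not yet been measured. It differs from compound 3 in one place: 4-ethylphenyl in place of methyl on an aromatic carbon. Every measured compound, whatever group sits on its side ring, reaches near-complete or greater inhibition at the tested concentration in this assay, so a change of this kind is expected to move the number little. Compound 4 is expected to give about 104%, within a range from 85% to 122%. The step of a number 3 percentage points higher from compound 3 to compound 4 (within the scatter) that this estimate means is expected to stay within the scatter, with no clear direction.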

Compound 4, a percentage reported as inhibition, at one concentration (the size of the read-out at that concentration, not a potency): 92.7%
For compound 4 the middle estimate is 11.3 percentage points above the measured one, within the range that was stated.
By their numbers in this assay, from the lowest: compounds 4, 1 and 3 (each within the scatter of the next); then compound 2.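

In this assay, within the data shown here, the step of a number 8.3 percentage points lower from compound 3 to compound 4 (within the scatter) gives the first direct look at a single change in this set, since no two of the earlier compounds differed in only one place. It shows that, on this aromatic carbon next to the ring nitrogen of the five-membered aromatic ring, a small methyl can give way to the much larger 4-ethylphenyl, with its six-membered aromatic ring of carbon only, without a difference that can be told from the scatter. Nothing available explains why the read-out holds at this position.

The read-out comes from one concentration and is not a potency. Compound 3 and compound 4 could still differ at lower concentrations, where a real gap between them might appear. Going by these compounds, it also remains open whether the same position would accept a group that brings in atoms other than carbon, such as an amine or a carboxylic acid placed on the phenyl ring in compound 4, or a hydroxyl at the end of a longer chain.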